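The compounds below may be only part of what the source reports. "The series", "measured", "known", "first", "only" and "open" are said of these compounds alone.

Working notes on the series. Of the compounds shown here, two have numbers so far. Compound 1 `CC(=O)Nc1cc(-c2ccc(OC[C@@H](N)CC(C)C)c(Cl)c2)ccn1` gives 86% in an ADME assay on microsomes from liver (Mus musculus) for metabolic stability, read by LC-MS, using NADPH, with a stated time of 10 min, tested at 0.5 uM; a lower number here means that less of the compound is left, a higher number that more of the compound is left. Compound 2 `CC(=O)Nc1cc(-c2ccc(OC[C@@H](N)CC(C)C)c(OC(F)(F)F)c2)ccn1` gives 35% in this assay. Among the compounds with values here, the single step between them, a number 51 percentage points lower from compound 1 to compound 2 (beyond the scatter), is the only measured step in the set, and it leaves compound 2 as the lowest of the two numbers, with compound 1 as its nearest neighbour far above it.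

Compound 3 `CC(=O)Nc1cc(-c2ccc(OC[C@@H](N)CC(C)C)c(C)c2)ccn1` is not yet measured. It differs from compound 2 in one place: methyl in place of trifluoromethoxy on an aromatic carbon. Within the data shown here, the change sits on the same aromatic carbon, ortho to the (2-amino-4-methylpentyl)oxy group and meta to a large group, that was varied in the one measured step, so that step bears directly on it. The step from compound 1 to compound 2 shows that exchanging the group at this carbon can move the read-out by a large amount. Among the measured compounds shown here, with only a chloro and a trifluoromethoxy compared, a methyl has no direct precedent here; the expectation is a rise of about a number 30 percentage points higher from compound 2 to compound 3 (beyond the scatter) back towards compound 1, but with a wide range.

Compound 3 is therefore estimated at 65%, between 40% and 90%.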

Compound 3, percent of the compound remaining: 64%
Compound 3: middle estimate off by 1 percentage points, on the high side; low and high end bracket the measured number.
By their numbers in this assay, from the lowest: compound 2; then compound 3; then compound 1.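

In this assay, the aromatic carbon ortho to the (2-amino-4-methylpentyl)oxy group now has three groups compared, and it no longer rests on a single contrast of chloro with trifluoromethoxy. Methyl in place of trifluoromethoxy gives a number 29 percentage points higher from compound 2 to compound 3 (beyond the scatter), so the low number of compound 2 is not shared by every replacement of chloro, yet a number 22 percentage points lower from compound 1 to compound 3 (beyond the scatter) shows that methyl does not match chloro either. All three compounds therefore stand apart beyond the scatter, in the order trifluoromethoxy, methyl, chloro from the lowest number, and no measurement is available that would explain this order.

What the compounds shown leave open is where a fluoro, a methoxy or a nitrile on this same carbon would fall in that order, and whether a hydrogen there would stand closer to compound 1 or to compound 2. From the compounds shown here alone, it also remains open whether the same order of chloro, methyl and trifluoromethoxy would hold if the acetamide or the (2-amino-4-methylpentyl)oxy group were replaced, for instance by a carboxylic acid or a longer chain.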